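Swapping a Trimethoxyphenyl Ring for a Methylphenyl Ring

The source may hold more compounds than are shown below. What is called first, only, known or untested is meant among the compounds shown, and "the series" means these compounds.

Of the compounds shown here, three built on one shared core have been tested in an ADME assay on J774.A1 cells (Mus musculus) for cytotoxicity, read by MTT assay, with a stated time of 72 h; on this read-out lower numbers stand for higher toxicity in this test and higher numbers for lower toxicity in this test. Compound 1 `CC1(c2ccc(-c3ccc(/C(N)=N\O)cc3)cc2)CC(S(=O)(=O)c2ccc(F)cc2)=C(c2ccc(/C(N)=N\O)cc2)O1` gives 3940 nM. Compound 2 `CC1(c2ccc(-c3cccc(/C(N)=N\O)c3)cc2)CC(S(=O)(=O)c2ccc(F)cc2)=C(c2ccc(/C(N)=N\O)cc2)O1` gives 11000 nM, and compound 3 `COc1cc(-c2ccc(C3(C)CC(S(=O)(=O)c4ccc(F)cc4)=C(c4ccc(/C(N)=N\O)cc4)O3)cc2)cc(OC)c1OC` gives 5220 nM. Compound 3 therefore holds the second highest of the three numbers: its nearest neighbour is compound 1, with a 1.3-fold higher number from compound 1 to compound 3 (0.12 log units; within the scatter), and its furthest is compound 2, with a 2.1-fold lower number from compound 2 to compound 3 (0.32 log units; beyond the scatter). The remaining step is a 2.8-fold higher number from compound 1 to compound 2 (0.45 log units; beyond the scatter).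

Compound 4 `Cc1ccc(-c2ccc(C3(C)CC(S(=O)(=O)c4ccc(F)cc4)=C(c4ccc(/C(N)=N\O)cc4)O3)cc2)cc1` is the untested compound; here (4-methylphenyl in place of 3,4,5-trimethoxyphenyl on an aromatic carbon). Within the data shown here, no measured step exchanges this same pair of rings, so the only guide is that every change at this position so far has moved the number only modestly, as seen in a 2.8-fold higher number from compound 1 to compound 2 (0.45 log units; beyond the scatter) and a 2.1-fold lower number from compound 2 to compound 3 (0.32 log units; beyond the scatter). For compound 4 the expected step is therefore a 1.2-fold lower number from compound 3 to compound 4 (0.06 log units; within the scatter), a change that may not clear the scatter. Compound 4 is thus estimated at 4500 nM in this assay, with a range from 2000 nM to 10000 nM.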

Compound 4, half-maximal cytotoxic concentration: 7910 nM
The estimate for compound 4 lay 1.8-fold (0.24 log units) below the measured number; the range from low to high includes it.
By their numbers in this assay, from the lowest: compounds 1, 3, 4 and 2 (each within the scatter of the next, the first and the last beyond it).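

In this assay, exchanging 3,4,5-trimethoxyphenyl for the smaller, oxygen-free 4-methylphenyl gives a 1.5-fold higher number from compound 3 to compound 4 (0.18 log units; within the scatter) and so produces no change that can be told from the scatter. Compound 4 also cannot be separated from the two compounds carrying the larger nitrogen- and oxygen-containing group, with a 1.4-fold lower number from compound 2 to compound 4 (0.14 log units; within the scatter) and a 2.0-fold higher number from compound 1 to compound 4 (0.30 log units; within the scatter), so this simple carbon-only ring lies within the scatter of all three others, even though compound 2 is separated from both compound 1 and compound 3. Nothing measured here explains where these numbers fall.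

From the compounds shown here alone, it remains open whether an amine or a carboxylic acid in place of the methyl would move the number beyond the scatter. Going by these compounds, how this ring exchange behaves in any other test also remains open.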